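The source may report more compounds than this note shows. Statements on the series, on what has been measured and on what is new or still open speak of the compounds shown alone.

Measured in a functional assay on MCF7 cells (Homo sapiens) for inhibition, read by sulforhodamine B assay, with a stated time of 48 h, tested at 10 uM; a higher number here means more inhibition at the concentration tested (going by the name of the read-out), a lower number less inhibition:
- compound 1 `COc1ccc(-c2cn3ccnc3c(-c3ccc4ncn(C5CCCCC5)c4c3)n2)cc1` gives 80.2%
- compound 2 `O=Cc1ccc(-c2cn3ccnc3c(-c3ccc4ncn(C5CCCCC5)c4c3)n2)cc1` gives 47.8%
- compound 3 `Brc1ccc(-c2cn3ccnc3c(-c3ccc4ncn(C5CCCCC5)c4c3)n2)cc1` gives 46.4%

Compound 1 stands highest of the three. The nearest is compound 2, with the step of a number 32.4 percentage points lower from compound 1 to compound 2 (beyond the scatter); the furthest is compound 3, with a number 33.8 percentage points lower from compound 1 to compound 3 (beyond the scatter). Between the two lower compounds the step of a number 1.4 percentage points lower from compound 2 to compound 3 (within the scatter) stays within the scatter.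

Compound 4 `FC(F)(F)c1cccc(-c2cn3ccnc3c(-c3ccc4ncn(C5CCCCC5)c4c3)n2)c1` is not yet measured. It differs from compound 1 by 3-(trifluoromethyl)phenyl in place of 4-methoxyphenyl on an aromatic carbon. The two steps that bear on this change are those leaving the methoxy of compound 1, and both were large and downward. A comparable downward step is therefore expected, a number 35.2 percentage points lower from compound 1 to compound 4 (beyond the scatter). For compound 4 the estimate in this assay is 45%, with a range from 25% to 65%.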

Compound 4, a percentage reported as inhibition, at one concentration (the size of the read-out at that concentration, not a potency): 19.9%
Compound 4: middle estimate off by 25.1 percentage points, on the high side; measured number below the stated range.
By their numbers in this assay, from the lowest: compound 4; then compounds 3 and 2 (each within the scatter of the next); then compound 1.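

In this assay, the 3-(trifluoromethyl)phenyl group gives the largest loss seen at this position (a number 60.3 percentage points lower from compound 1 to compound 4 (beyond the scatter)), so leaving 4-methoxyphenyl does not always end at the level of the bromo and formyl compounds. Compound 4 also stands clear of both (a number 26.5 percentage points lower from compound 3 to compound 4 (beyond the scatter); a number 27.9 percentage points lower from compound 2 to compound 4 (beyond the scatter)). No measurement offers an explanation for this loss.

This change swaps the group and also moves it on the phenyl ring, and the compounds shown cannot separate those two parts. On these data alone, whether an amine or a carboxylic acid on that ring would retain the level of compound 1 remains open.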